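Cytotoxicity of a hexyloxy analogue, estimated from three limits

This account rests on a few compounds, and the source may have more. Where it says the series, first, only, none or still open, it means among the compounds named here.

compound 1 `CCOc1nc(N)nc2c1ncn2/C=C1/CC1(CO)CO` — > 20000 nM
compound 2 `CN(C)c1nc(N)nc2c1ncn2/C=C1/CC1(CO)CO` — > 20000 nM
compound 3 `CCCOc1nc(N)nc2c1ncn2/C=C1/CC1(CO)CO` — > 20000 nM

In an ADME assay on BCBL1 cells (Homo sapiens) for cytotoxicity, with a stated time of 7 days (on this read-out higher numbers stand for lower toxicity in this test and lower numbers for higher toxicity in this test), compound 1 gives > 20000 nM, which is a limit of the assay and not a number. Compound 2 likewise gives > 20000 nM, a limit. Compound 3 gives > 20000 nM, again a limit. All three therefore share (the limit of > 20000 nM in this assay, at which 3 of the 3 values shown sit), and the steps between them cannot be read: a step that the two limits leave unreadable from compound 1 to compound 2, a step that the two limits leave unreadable from compound 1 to compound 3 and a step that the two limits leave unreadable from compound 2 to compound 3 are each left unreadable by the two limits.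

Compound 4 `CCCCCCOc1nc(N)nc2c1ncn2/C=C1/CC1(CO)CO` differs from compound 1 by butyl in place of hydrogen on a saturated chain carbon, two bonds along the chain from an oxygen on an aromatic ring. Among the compounds with values here, the one measured step that bears on it is a step that the two limits leave unreadable from compound 1 to compound 3, a smaller lengthening of the same chain, and its size is not readable. Within the data shown here, no measured step here gives a direction, so the step that the limit leaves unreadable from compound 1 to compound 4 is expected to be small, with a chance that the value again comes out only as a limit. Compound 4 is therefore estimated at 25000 nM, within a range from 7000 nM to 90000 nM.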

Compound 4, half-maximal cytotoxic concentration: > 20000 nM
Compound 4: a limit, no number; the forecaster's own chance of this, stated with the estimate: 60%; the middle value is on the limit's open side.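

Compound 4 gives > 20000 nM in this assay, which is a limit of the assay and not a number. Its steps from compound 1, compound 2 and compound 3 therefore cannot be read: the limit of > 20000 nM in this assay, at which 4 of the 4 values shown sit. The compounds shown leave open whether the ethoxy, dimethylamino, propoxy and hexyloxy compounds differ in cytotoxicity at all.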